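The source may hold more compounds than are shown below. What is called first, only, known or untested is meant among the compounds shown, and "the series" means these compounds.

Series notes. The set has three measured compounds and one open one. Compound 1 `Fc1ccc2[nH]c(-c3cn(-c4ccccc4)nc3-c3ccc(Cl)cc3)nc2c1` gives 4610 nM in a functional assay on A549 cells (Homo sapiens) for antiproliferative activity, read by MTT assay, with a stated time of 48 h; a lower number here means a stronger inhibitor, a higher number a weaker inhibitor. Compound 2 `Clc1ccc(-c2nn(-c3ccccc3)cc2-c2nc3cc(Cl)ccc3[nH]2)cc1` gives 1340 nM in this assay, and compound 3 `COc1ccc2[nH]c(-c3cn(-c4ccccc4)nc3-c3ccc(Cl)cc3)nc2c1` gives 2420 nM. The step of a 3.4-fold lower number from compound 1 to compound 2 (0.54 log units; beyond the scatter) is the only one here beyond the scatter; a 1.9-fold lower number from compound 1 to compound 3 (0.28 log units; within the scatter) and a 1.8-fold higher number from compound 2 to compound 3 (0.26 log units; within the scatter) are not.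

Open compound 4 `COc1ccc(-c2nn(-c3ccccc3)cc2-c2nc3cc(F)ccc3[nH]2)cc1` differs from compound 1 by methoxy in place of chloro on an aromatic carbon. The same kind of change, not the same, runs from compound 2 to compound 3: methoxy in place of chloro on an aromatic carbon, on the fused ring, meta and para to a fused ring, rather than on the six-membered ring of carbon only, para to a large group. The cores of compound 1 and compound 2 also differ, by fluoro in place of chloro on an aromatic carbon. The measured precedent, a 1.8-fold higher number from compound 2 to compound 3 (0.26 log units; within the scatter), is within the scatter, so a change of about that size, or none, is expected in this assay: a 1.4-fold higher number from compound 1 to compound 4 (0.15 log units; within the scatter). With compound 1 at 4610 nM as the anchor, compound 4 is estimated at 6500 nM, with a range from 2500 nM to 17000 nM, resting on one precedent at a different place only.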

Compound 4, half-maximal inhibitory concentration: 1980 nM
Estimate against measurement, compound 4: 3.3-fold (0.52 log units) above; the whole stated range lies above it.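

In this assay, replacing 4-chlorophenyl with 4-methoxyphenyl gives a 2.3-fold lower number from compound 1 to compound 4 (0.37 log units; beyond the scatter). Set beside the earlier exchange of chloro for methoxy, the step does not keep its size or direction from one core to the other: the same change on two cores in this assay, a 1.8-fold higher number (0.26 log units; within the scatter) from compound 2 to compound 3 and a 2.3-fold lower number (0.37 log units; beyond the scatter) from compound 1 to compound 4, 4.2-fold (0.62 log units) apart, beyond the scatter of two such steps. For the compounds shown here, with a single pair on each core and the two exchanges at different places on the molecule, this shows only that the step cannot be carried over unchanged, not whether the core or the place of the change accounts for the gap.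

From the compounds shown here alone, whether the exchange of 4-chlorophenyl for 4-methoxyphenyl gives a similar step on the core of compound 2 or of compound 3 remains open, and a further pair on any of these cores would help to separate core from place. Also open, going by these compounds, is how an amine, a carboxylic acid or a longer chain such as ethoxy would read in that same place.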